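Replacing the indole hydrazone with a difluorophenyl ketone hydrazone

The source may report more compounds than this note shows. Statements on the series, on what has been measured and on what is new or still open speak of the compounds shown alone.

Of the compounds shown here, two sharing the same core have been measured in an ADME assay on HT-29 cells (Homo sapiens) for inhibition, read by MTT assay, with a stated time of 72 h; a lower number here means a stronger inhibitor, a higher number a weaker inhibitor. Compound 1 `CN(C)C/C=C/C(=O)Nc1cccc(Nc2nc(N/N=C/c3ccc(F)cc3F)ncc2Cl)c1` gives 2920 nM in this assay, and compound 2 `CN(C)C/C=C/C(=O)Nc1cccc(Nc2nc(N/N=C/c3c[nH]c4ccccc34)ncc2Cl)c1` gives 9680 nM. For the measured compounds named here, compound 2 thus stands with the highest of the two numbers; its nearest neighbour is compound 1, and the only measured step, a 3.3-fold higher number from compound 1 to compound 2 (0.52 log units; beyond the scatter), consists of 1H-indol-3-yl taking the place of 2,4-difluorophenyl on a carbon with a double bond to nitrogen.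

Compound 3 `C/C(=N\Nc1ncc(Cl)c(Nc2cccc(NC(=O)/C=C/CN(C)C)c2)n1)c1ccc(F)cc1F` is not yet measured. It differs from compound 2 by a group of 11 heavy atoms (8 carbon, 1 nitrogen, 2 fluorine; one six-membered aromatic ring of carbon only) in place of a group of 11 heavy atoms (9 carbon, 2 nitrogen; one five-membered aromatic ring with 1 hetero atom, one six-membered aromatic ring of carbon only), on a nitrogen on an aromatic ring, on a nitrogen whose other neighbour is an aromatic carbon. Going by the values given here, the entering group carries a 2,4-difluorophenyl ring, as in compound 1, so the change largely reverses the single measured step, though compound 3 and compound 1 are not identical. Since the step from compound 1 to compound 2 raised the number modestly, compound 3 is expected to bring the number back down, with a 3.0-fold lower number from compound 2 to compound 3 (0.48 log units; beyond the scatter), landing near compound 1. The estimate for compound 3 in this assay is 3200 nM, within a range of 1200 nM to 8500 nM.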

Compound 3, half-maximal inhibitory concentration: 3460 nM
Compound 3: the middle estimate sits 1.1-fold (0.03 log units) below what was measured; measured number inside the range.
By their numbers in this assay, from the lowest: compounds 1 and 3 (each within the scatter of the next); then compound 2.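

In this assay, for the compounds shown here, the 2,4-difluorophenyl group again gives a lower number than the 1H-indol-3-yl group, with a 2.8-fold lower number from compound 2 to compound 3 (0.45 log units; beyond the scatter), and the earlier drop is thus seen a second time on a group that differs from the one in compound 1. Setting the group of 11 heavy atoms of compound 3 in place of the group of 10 heavy atoms of compound 1 gives a 1.2-fold higher number from compound 1 to compound 3 (0.07 log units; within the scatter), so the extra carbon on this group, on a nitrogen on an aromatic ring, leaves no difference that can be read here. Among these three compounds, the number therefore follows the aromatic ring system at this position and not the added carbon, with compound 1 and compound 3 standing together and compound 2 apart from them.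

The compounds shown leave open how a longer chain such as ethyl on the same carbon would read, and whether a pyridine ring or a 4-fluorophenyl ring would stay with compound 1 and compound 3 or move toward compound 2. Nothing given here bears on what lies behind these differences.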